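Lengthening the chain from compound 3 to compound 4

The source may report more compounds than this note shows. Statements on the series, on what has been measured and on what is new or still open speak of the compounds shown alone.

Compound 1 `CCCCCCCC#Cc1cc2cn(COCCO)c(=O)nc2o1`: > 50000 nM
Compound 2 `CCCCCCCCC#Cc1cc2cn(COCCO)c(=O)nc2o1`: 42000 nM
Compound 3 `CCCCC#Cc1cc2cn(COCCO)c(=O)nc2o1`: > 50000 nM

In a functional assay on HEL cells (Homo sapiens) (a higher number here means that more compound is tolerated, a lower number that less compound is tolerated), compound 3 gives > 50000 nM, which is a limit and not a number. Compound 1 gives > 50000 nM, which is also a limit. Together they make up (the limit of > 50000 nM in this assay, at which 2 of the 3 values shown sit). For the measured compounds named here, compound 2 is the only one with a true number, 42000 nM.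

Compound 4 `CCCCCCCCCC#Cc1cc2cn(COCCO)c(=O)nc2o1` has not yet been measured. The change that leads to it is pentyl in place of hydrogen on a saturated chain carbon, four bonds along the chain from a triple-bonded carbon.

The closest measured change swaps butyl for hydrogen at that same carbon, and it gives an at least 1.1-fold higher number from compound 2 to compound 3 (0.07 log units; that floor lies within the scatter). The chain change between the other pair gives an at least 1.1-fold lower number from compound 1 to compound 2 (0.07 log units; that floor lies within the scatter). Both are only floors, and both lie within the scatter. The third comparison, a step that the two limits leave unreadable from compound 1 to compound 3, cannot be read at all.

These steps give weak guidance, so only a modest move towards less compound being tolerated is expected in this assay, with compound 2 at 42000 nM as the nearest guide. The expected change is an at least 1.2-fold lower number from compound 3 to compound 4 (0.09 log units; that floor lies within the scatter). For compound 4, the estimated value is 40000 nM, with an expected range of 20000 nM to 70000 nM.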

Compound 4, half-maximal cytotoxic concentration: > 50000 nM
Compound 4 was reported as a limit; the forecaster's own chance of this, stated with the estimate: 35%; middle value at least 1.2-fold (0.09 log units) away from the limit.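

In this assay the result for compound 4 is > 50000 nM as a limit and not a number. One more methyl on a saturated chain carbon, eight bonds along the chain from a triple-bonded carbon, gives an at least 1.1-fold higher number from compound 2 to compound 4 (0.07 log units; that floor lies within the scatter) and so shows no readable change at this end of the chain, which means the true number of compound 2 does not mark the start of a fall in the amount tolerated as the chain grows. The steps that join compound 4 to compound 1 and to compound 3 cannot be read, and the pentyl change leaves almost the whole series resting on one limit: the limit of > 50000 nM in this assay, at which 3 of the 4 values shown sit.

From the compounds shown here alone, how far the true values of compound 1, compound 3 and compound 4 lie from that limit stays unknown, so chain length can hardly be ranked with these compounds. Also open, going by these compounds, is whether a longer chain, or a chain carrying an amine or a carboxylic acid in place of the plain pentyl, would give a true number in this assay and show a clear difference from compound 2.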